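Methyl to tert-butyl, from compound 2 to compound 4

The compounds below may be only part of what the source reports. "The series", "measured", "known", "first", "only" and "open" are said of these compounds alone.

Measured compounds: compound 1 `Cc1ccc(-c2cn(C/C=C3\OC(=O)C(OCc4ccccc4)=C3OCc3ccccc3)nn2)cc1`, which in a functional assay on MDA-MB-231 cells (Homo sapiens) for antiproliferative activity, read by MTT assay, with a stated time of 24 h (on this read-out lower numbers stand for stronger inhibition and higher numbers for weaker inhibition), gives > 100000 nM, a limit of the assay and not a number. Compound 2 `Cc1ccc(-c2cn(CCC3(O)NC(=O)C(OCc4ccccc4)=C3OCc3ccccc3)nn2)cc1`, which in this assay gives 82200 nM. Compound 3 `CC(C)(C)c1ccc(-c2cn(C/C=C3\OC(=O)C(OCc4ccccc4)=C3OCc3ccccc3)nn2)cc1`, which in this assay gives 51200 nM.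

Compound 2 stands highest of the two numbers; compound 3 lies within the scatter of it, and compound 1 contributes only a limit.

Compound 4 `CC(C)(C)c1ccc(-c2cn(CCC3(O)NC(=O)C(OCc4ccccc4)=C3OCc3ccccc3)nn2)cc1` differs from compound 2 by tert-butyl in place of methyl on an aromatic carbon. The same change has been measured once, in an at least 1.9-fold lower number from compound 1 to compound 3 (0.29 log units; that floor lies within the scatter), and since compound 1 sits at the limit of > 100000 nM in this assay, at which 1 of the 3 values shown sits, that step is only a floor. A lowering of similar size is expected, so the step of a 1.8-fold lower number from compound 2 to compound 4 (0.26 log units; within the scatter) is estimated. Compound 4 is expected to give 45000 nM, within 20000 nM to 100000 nM.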

Compound 4, half-maximal inhibitory concentration: > 100000 nM
Compound 4 ended at the assay's limit; the forecaster's own chance of this, stated with the estimate: 15%; at least 2.2-fold (0.34 log units) between middle value and limit.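

In this assay compound 4 gives > 100000 nM as a limit of the assay and not a number. On this core, tert-butyl in place of methyl gives an at least 1.2-fold higher number from compound 2 to compound 4 (0.08 log units; that floor lies within the scatter) on the aromatic carbon, so the lowering hoped for from the first pair does not show here. The larger group therefore has no readable effect of one direction across the two cores: the same change on two cores in this assay, an at least 1.9-fold lower number (0.29 log units; that floor lies within the scatter) from compound 1 to compound 3 and an at least 1.2-fold higher number (0.08 log units; that floor lies within the scatter) from compound 2 to compound 4; the limit leaves it open whether they differ

Still open, going by these compounds, is how far compound 4 lies past the limit, and so the true size of this step. Also open, on these data alone, is whether an amine or a carboxylic acid in place of methyl would give a measurable value on either core.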